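A halogen swap on the hydrazone aryl ring

The source may report more compounds than this note shows. Statements on the series, on what has been measured and on what is new or still open speak of the compounds shown alone.

Measured so far:
compound 1 `O=C(COc1cccc2ccccc12)N/N=C/c1ccc(Cl)cc1` with 87.6 ug/mL
compound 2 `C/C(=N\NC(=O)COc1cccc2ccccc12)c1cccc([N+](=O)[O-])c1` with 12.1 ug/mL

In an ADME assay on MT4 cells (Homo sapiens) for cytotoxicity, read by MTT assay, with a stated time of 4 days (a higher number here means that more compound is tolerated, a lower number that less compound is tolerated), compound 1 gives 87.6 ug/mL and stands highest of the two numbers; compound 2 gives 12.1 ug/mL, a lower value beyond the scatter. Compound 3 `O=C(COc1cccc2ccccc12)N/N=C/c1ccccc1Br` is not yet measured. It differs from compound 1 by 2-bromophenyl in place of 4-chlorophenyl on a carbon with a double bond to nitrogen. Within the data shown here, no comparable step between measured compounds is known here, so the expectation rests on compound 1 alone. For compound 3 the expected step from compound 1 is a 1.2-fold lower number from compound 1 to compound 3 (0.07 log units; within the scatter), that is, no change beyond the scatter in this assay. Compound 3 is therefore estimated at 75 ug/mL, within a range of 30 ug/mL to 180 ug/mL.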

Compound 3, half-maximal cytotoxic concentration: 11.4 ug/mL
For compound 3 the middle estimate is 6.6-fold (0.82 log units) above the measured one; the whole stated range lies above it.
By their numbers in this assay, from the lowest: compounds 3 and 2 (each within the scatter of the next); then compound 1.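

Replacing 4-chlorophenyl with 2-bromophenyl on a carbon with a double bond to nitrogen gives a 7.7-fold lower number from compound 1 to compound 3 (0.89 log units; beyond the scatter) in this assay, so the tolerated concentration depends strongly on the aryl group at this position. The halogen and its place on the ring change together, and this single step cannot separate the two. Nothing available here explains the step.

Going by these compounds, it remains open whether 4-bromophenyl or 2-chlorophenyl would behave more like compound 1 or compound 3. On these data alone, the effect of an amine or a carboxylic acid on this ring also remains open.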